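A few compounds are considered here, and "the series" means these few. Any claim that something is new, unique, unknown or untested is made for them only; others in the source may bear on it.

Measured in an ADME assay on microsomes from liver (Rattus norvegicus) for metabolic stability; on this read-out lower numbers stand for a shorter-lived compound and higher numbers for a longer-lived compound:
- Compound 1 `FC(F)(F)c1ccc(NCCNc2ncc(-c3ncc[nH]3)c(-c3ccc(Cl)cc3Cl)n2)nc1`: > 0.5 h (a limit, not a number)
- Compound 2 `Nc1nc(NCCNc2ncc(-c3ncc[nH]3)c(-c3ccc(Cl)cc3)n2)ccc1[N+](=O)[O-]`: > 0.5 h (a limit, not a number)
- Compound 3 `Nc1nc(NCCNc2ncc(-c3ncc[nH]3)c(-c3ccc(F)cc3F)n2)ccc1[N+](=O)[O-]`: > 0.5 h (a limit, not a number)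

Compound 2 has no exact half-life, only the limit > 0.5 h. Compound 1 and compound 3 likewise give only limits, so the series offers no number to serve as a baseline: the limit of > 0.5 h in this assay, at which 3 of the 3 values shown sit.

Compound 4 `Nc1nc(NCCNc2ncc(-c3ncc[nH]3)c(-c3cc(F)ccc3F)n2)ccc1[N+](=O)[O-]` departs from compound 2 in one place: 2,5-difluorophenyl in place of 4-chlorophenyl on an aromatic carbon. In words, 2,5-difluorophenyl stands in place of 4-chlorophenyl on an aromatic carbon, ortho to a 1H-imidazol-2-yl group.

Among the compounds with values here, the one measured step that bears on this change is a step that the two limits leave unreadable from compound 2 to compound 3, where 2,4-difluorophenyl takes the place of 4-chlorophenyl. Its size cannot be read, so it gives no direction to carry over. Compound 3 is the closest measured relative of compound 4. Compound 3 reports > 0.5 h, which is again a limit.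

In this assay, no shift beyond the usual scatter is therefore expected, and the estimated step is a step that the limit leaves unreadable from compound 2 to compound 4. A result reported only as a limit would be unsurprising. For compound 4 the estimated half-life is 0.6 h, with an expected range from 0.3 h to 1.5 h.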

Compound 4, half-life: > 0.5 h
Compound 4: a limit, no number; the forecaster's own chance of this, stated with the estimate: 65%; the middle value does not contradict the limit.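

In this assay compound 4 gives > 0.5 h, which is a limit and not a number. The steps to compound 4 from compound 2 and compound 3 therefore cannot be read: the limit of > 0.5 h in this assay, at which 4 of the 4 values shown sit.

The compounds shown leave open the actual half-life of each compound, and whether 4-chlorophenyl, 2,4-difluorophenyl and 2,5-difluorophenyl differ at all on this read-out.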